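A Fluoro Substituent Tested on a Weak Core

The source may hold more compounds than are shown below. What is called first, only, known or untested is meant among the compounds shown, and "the series" means these compounds.

Of the compounds shown here, three have been measured in a functional assay on MCF7 cells (Homo sapiens) for antiproliferative activity, read by MTT assay, with a stated time of 72 h; a lower number here means a stronger inhibitor of growth, a higher number a weaker inhibitor of growth. Compound 1 `c1ccc(/N=c2\ssnc2-c2ccccc2)cc1` gives 10000 nM in this assay. Compound 2 `c1ccc(/N=c2\ssnc2-c2cccs2)cc1` reaches only a limit of the assay, > 10000 nM. Compound 3 `S=c1ssnc1-c1ccccc1` likewise sits at a limit, > 10000 nM. Compound 3 therefore stands at the weak end of what the assay can report, a point shared by two of the three values (the limit of > 10000 nM in this assay, at which 2 of the 3 values shown sit). Within the data shown here, the single measured step, a number no lower from compound 1 to compound 2 (the limit leaves the size open), has no readable size. Compound 4 `Fc1ccc(-c2nssc2=S)cc1` differs from compound 3 by fluoro in place of hydrogen on an aromatic carbon. Among the measured compounds shown here, no measured step bears on this change, and the core already lies beyond the assay's reach, so no shift beyond the scatter is expected. Compound 4 is expected to give 15000 nM in this assay, within 5000 nM to 50000 nM. The step that the limit leaves unreadable from compound 3 to compound 4 is estimated to be small.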

Compound 4, concentration for 50% growth inhibition: > 10000 nM
Compound 4: a limit, no number (the forecaster's own chance of this, stated with the estimate: 75%); the middle value does not contradict the limit.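

Compound 3 and compound 4 both sit at a limit of this assay, so no step between them can be read: the limit of > 10000 nM in this assay, at which 3 of the 4 values shown sit.

From the compounds shown here alone, whether fluoro in place of hydrogen on an aromatic carbon changes growth inhibition at all remains open.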